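Moving the Halogen on the Aryl Ketone of a Benzoxaborole Chalcone

The source may report more compounds than this note shows. Statements on the series, on what has been measured and on what is new or still open speak of the compounds shown alone.

Measured compounds:
compound 1, `O=C(/C=C/c1ccc2c(c1)B(O)OC2)c1ccc(F)cc1`, 2800 nM
compound 2, `O=C(/C=C/c1ccc2c(c1)B(O)OC2)c1ccc(Br)cc1`, 9900 nM

Both compounds share the same core and differ only in the halogen on the aryl ketone. Within the data shown here, in a functional assay on HCT-116 cells (Homo sapiens) for cytotoxicity, read by MTT assay, with a stated time of 48 h (on this read-out lower numbers stand for stronger inhibition and higher numbers for weaker inhibition), compound 1 gives 2800 nM, whereas compound 2 gives 9900 nM, the higher of the two numbers; the one measured step, a 3.5-fold higher number from compound 1 to compound 2 (0.55 log units; beyond the scatter), is beyond the scatter and marks compound 2 as the weaker of the pair.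

Compound 3, `O=C(/C=C/c1ccc2c(c1)B(O)OC2)c1ccccc1F`, is not yet measured. It differs from compound 2 by 2-fluorophenyl in place of 4-bromophenyl on a carbonyl carbon, so a fluorine returns to the ring, though as a 2-fluorophenyl group, which compound 1 does not carry.

Among the measured compounds shown here, the only step that bears on this change is the fluoro-to-bromo step from compound 1 to compound 2, which raised the number by a modest amount. Reversing the halogen is expected to lower the number again, but the fluorine now sits in a group that has not been tested, so the expectation is loose. Compound 3 is expected to give 3500 nM, with a range of 1200 nM to 10000 nM, an expected step of a 2.8-fold lower number from compound 2 to compound 3 (0.45 log units; beyond the scatter).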

Compound 3, half-maximal inhibitory concentration: 4200 nM
Estimate against measurement, compound 3: 1.2-fold (0.08 log units) below, within the range that was stated.
By their numbers in this assay, from the lowest: compounds 1 and 3 (each within the scatter of the next); then compound 2.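

In this assay, replacing 4-bromophenyl with 2-fluorophenyl on the carbonyl carbon gives a 2.4-fold lower number from compound 2 to compound 3 (0.37 log units; beyond the scatter), so a fluorinated ring again separates from the bromo compound, even with the fluorine placed differently. The more direct test of placement is the change from 4-fluorophenyl to 2-fluorophenyl, which gives a 1.5-fold higher number from compound 1 to compound 3 (0.18 log units; within the scatter); this step cannot distinguish the two fluorine placements, so in this pair, moving the fluorine has no measurable effect on the number. No supporting measurement is available to explain why either step has the size it does.

The comparison of compound 2 with compound 3 changes both the halogen and its placement, so it cannot show how much of that step belongs to each change, and bromine has been seen here only in the 4-bromophenyl group. Also open, going by these compounds, is how the number would respond to a plain phenyl group carrying no halogen, or to a ring bearing an amine or a carboxylic acid in place of the halogen.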